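Replacing a Propanoyl Group with a Sulfur-Bearing Chain

This account rests on a few compounds, and the source may have more. Where it says the series, first, only, none or still open, it means among the compounds named here.

Measured compounds:
compound 1, `CCNC(=O)NCC1CCc2ccccc2N1`: 30%
compound 2, `CCC(=O)NCC1CCc2ccccc2N1`: 37%

In a functional assay on CHO cells with melatonin receptor type 1A (Homo sapiens) as the target, read by GTPgammaS binding, with a stated time of 1 h (a higher number here means a larger maximal response, a lower number a smaller maximal response), compound 2 gives 37%. Among the compounds with values here, this is the highest of the two numbers available, but its only neighbour is compound 1, which gives 30%, and the two lie within the usual scatter of each other, so neither can be called the stronger. Within the data shown here, the single measured step, a number 7 percentage points higher from compound 1 to compound 2 (within the scatter), is the only comparison at hand.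

Compound 3, `CCNC(=S)NCC1CCc2ccccc2N1`, is the next member. Relative to compound 2 the change is a group of 5 heavy atoms (3 carbon, 1 nitrogen, 1 sulfur; no ring) in place of a group of 4 heavy atoms (3 carbon, 1 oxygen; no ring), on an amine nitrogen. The step from compound 1 to compound 2 covers, in reverse, part of the same change at the same position, with a carbonyl in place of the sulfur. That step, a number 7 percentage points higher from compound 1 to compound 2 (within the scatter), did not exceed the scatter. Nothing measured here speaks to swapping oxygen for sulfur. Compound 3 is therefore expected to stay close to its neighbours, with a number 4 percentage points lower from compound 2 to compound 3 (within the scatter) as the anticipated step. Compound 3 is estimated at 33%, with a likely range from 15% to 55%.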

Compound 3, largest response reached (Emax), in percent of the reference or control that the assay uses: 35%
Beside the measured number, compound 3's estimate is 2 percentage points below it; the range from low to high includes it.
By their numbers in this assay, from the lowest: compounds 1, 3 and 2 (each within the scatter of the next).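

In this assay sulfur in place of the carbonyl oxygen gives a number 5 percentage points higher from compound 1 to compound 3 (within the scatter) and so shows that this exchange alone, on an amine nitrogen, brings no readable change in maximal response. Replacing propanoyl with the sulfur-bearing chain, a group with 1 hydrogen-bond donor where propanoyl has 0, gives a number 2 percentage points lower from compound 2 to compound 3 (within the scatter) and so extends the result to a change of both the atom on the double bond and the group attached to it, leaving all three compounds within the scatter of one another. No separate finding bears on why the response stays so similar across these exchanges.

The compounds shown leave open whether a longer chain such as butyl, or a ring such as cyclopropyl or phenyl, in place of the ethyl group would move the maximal response beyond the scatter. They also leave open how a sulfonyl group or a carboxylic acid on the same amine nitrogen would compare with the groups seen so far.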